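This account rests on a few compounds, and the source may have more. Where it says the series, first, only, none or still open, it means among the compounds named here.

Measured compounds:
Compound 1, `CCCCCCCC(C)OC(=O)NC(=O)Nc1c(C(C)C)cccc1C(C)C`: in an assay on microsomes from intestine for inhibition of acyl-CoA:cholesterol acyltransferase (Oryctolagus cuniculus) (a higher number here means a weaker inhibitor, a lower number a stronger inhibitor), compound 1 gives 390 nM.
Compound 2, `CCCCCCCCC(C)OC(=O)NC(=O)Nc1c(C(C)C)cccc1C(C)C`: in this assay compound 2 gives 750 nM.
Compound 3, `CCCCCCCCOC(=O)NC(=O)Oc1c(C(C)C)cccc1C(C)C`: in this assay compound 3 gives 250 nM.

Compounds 1 and 2 share one core and differ by one change, (methyl in place of hydrogen on a saturated chain carbon, eight bonds along the chain from an oxygen next to a carbonyl group). That change made a 1.9-fold higher number from compound 1 to compound 2 (0.28 log units; within the scatter). Compound 3 has a different core; how the core of compound 3 differs from the core of compound 1 is not broken down here. Among the three numbers compound 3 stands lowest, with compound 1 closest and compound 2 furthest.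

Compound 4, `CCCCCCCC(C)OC(=O)NC(=O)Oc1c(C(C)C)cccc1C(C)C`, is not yet measured. It differs from compound 3 by methyl in place of hydrogen on a saturated chain carbon bound to an oxygen next to a carbonyl group and a saturated chain carbon. Within the data shown here, this is the same kind of change as the one from compound 1 to compound 2, though the place is not the same: there the methyl sits on a saturated chain carbon eight bonds along the chain from an oxygen next to a carbonyl group, here on a saturated chain carbon bound to an oxygen next to a carbonyl group and a saturated chain carbon. Resting on compound 1 and compound 2 with a 1.9-fold higher number from compound 1 to compound 2 (0.28 log units; within the scatter), compound 4 is expected to show a 1.7-fold higher number from compound 3 to compound 4 (0.23 log units; within the scatter) in this assay, a step of about the same size. Compound 4 is therefore estimated at 420 nM, within 200 nM to 900 nM.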

Compound 4, half-maximal inhibitory concentration: 97 nM
Beside the measured number, compound 4's estimate is 4.3-fold (0.64 log units) above it; measured number outside the range, below it.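

In this assay the methyl in place of hydrogen gave a 2.6-fold lower number from compound 3 to compound 4 (0.41 log units; beyond the scatter), and this step did not match the earlier one on the other core: the same change on two cores in this assay, a 1.9-fold higher number (0.28 log units; within the scatter) from compound 1 to compound 2 and a 2.6-fold lower number (0.41 log units; beyond the scatter) from compound 3 to compound 4, 5.0-fold (0.70 log units) apart, beyond the scatter of two such steps For this one pair of steps, then, the size of the step on one core was a poor guide to the step on the other. It does not show what lies behind the gap, as the methyl sits at a different place in each step and the cores differ as well, and two steps cannot separate place from core.

The compounds shown leave open whether a methyl on the saturated chain carbon bound to an oxygen next to a carbonyl group would give a similar step on the core of compound 1, which would separate the role of place from that of core. They also leave open how an ethyl group or a longer chain on that same carbon would read on either core.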